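Swapping fluoro for cyano at the same aromatic carbon

The source may report more compounds than this note shows. Statements on the series, on what has been measured and on what is new or still open speak of the compounds shown alone.

Compound 2 `O=[N+]([O-])c1ccc(CN2CCC(n3cc(CC(OCc4cc(-c5cccc(F)c5)no4)c4ccc(Br)cc4)nn3)CC2)cc1` carries a 3-fluorophenyl group on the shared core. In a functional assay on MDA-MB-468 cells (Homo sapiens) for cytotoxicity, with a stated time of 48 h (a higher number here means a weaker inhibitor, a lower number a stronger inhibitor), compound 2 gives 3000 nM. Among the compounds with values here, only one other compound has been measured, compound 1 `O=[N+]([O-])c1ccc(CN2CCC(n3cc(CC(OCc4cc(-c5ccc(F)cc5)no4)c4ccc(Br)cc4)nn3)CC2)cc1`, which in this assay gives 4000 nM; the two stand within the scatter of each other, as a 1.3-fold lower number from compound 1 to compound 2 (0.12 log units; within the scatter) shows, so compound 2 cannot be set apart from compound 1 on these numbers. Compound 3 `N#Cc1cccc(-c2cc(COC(Cc3cn(C4CCN(Cc5ccc([N+](=O)[O-])cc5)CC4)nn3)c3ccc(Br)cc3)on2)c1` differs from compound 2 in one place: cyano in place of fluoro on an aromatic carbon. Within the data shown here, the single measured step, 4-fluorophenyl to 3-fluorophenyl, concerns a move of the same fluoro around the ring and stayed within the scatter; no measured pair speaks to exchanging fluoro for cyano on that carbon. The expectation therefore rests on the value of compound 2 alone. Compound 3 is expected to give a number close to that of compound 2, with a step of no change at the digits printed from compound 2 to compound 3 (within the scatter) that is not expected to go beyond the scatter in either direction. The estimate for compound 3 in this assay is 3000 nM, with a range from 1000 nM to 9000 nM.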

Compound 3, half-maximal inhibitory concentration: > 25000 nM
Compound 3 ended at the assay's limit; the forecaster's own chance of this, stated with the estimate: 5%; at least 8.3-fold (0.92 log units) between middle value and limit.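

Within the data shown here, until now the only measured change on this ring was a move of the fluoro, which stayed within the scatter. Among these compounds, the exchange of fluoro for cyano on the same aromatic carbon is the first change here to go beyond it, giving in this assay an at least 8.3-fold higher number from compound 2 to compound 3 (0.92 log units; beyond the scatter). Measured against the other fluorophenyl compound the picture is the same, with an at least 6.2-fold higher number from compound 1 to compound 3 (0.79 log units; beyond the scatter), so this ring position is not indifferent to the group it carries, even though the two fluoro compounds could not be told apart. Compound 3 stands at a limit of the assay and not at a number, so both steps give only a minimum and their true size stays unknown: the limit of > 25000 nM in this assay, at which 1 of the 3 values shown sits.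

With only fluoro and cyano on this ring, the compounds shown do not tell whether a chloro, a methoxy or an amine on that carbon would read like the fluoro compounds or like compound 3. They also give no reason why the cyano compound stands apart, and they leave open whether the same exchange would have the same outcome on a core carrying something other than the bromo group.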